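Swapping the Naphthol for a Hydroxymethoxyphenyl Ring

This account rests on a few compounds, and the source may have more. Where it says the series, first, only, none or still open, it means among the compounds named here.

Measured so far:
- Compound 1, `COc1ccc(/C=N/NC(=O)Nc2ccc(Oc3ccnc(-c4nncn4CCN(C)C)c3)c(F)c2)c(OC)c1`: 2820 nM
- Compound 2, `COc1ccc(/C=N/NC(=O)Nc2ccc(Oc3ccnc(-c4nncn4CCN(C)C)c3)c(F)c2)c(OC)c1OC`: 6680 nM
- Compound 3, `CN(C)CCn1cnnc1-c1cc(Oc2ccc(NC(=O)N/N=C/c3c(O)ccc4ccccc34)cc2F)ccn1`: 880 nM

In a functional assay on A549 cells (Homo sapiens) for cytotoxicity, read by MTT assay, with a stated time of 72 h (a higher number here means a weaker inhibitor, a lower number a stronger inhibitor), compound 3 gives the lowest of the three numbers, beyond the scatter from both others. Compound 4, `COc1cc(/C=N/NC(=O)Nc2ccc(Oc3ccnc(-c4nncn4CCN(C)C)c3)c(F)c2)ccc1O`, has not yet been measured. It differs from compound 3 in one place: 4-hydroxy-3-methoxyphenyl in place of 2-hydroxynaphthalen-1-yl on a carbon with a double bond to nitrogen. Among the measured compounds shown here, two measured steps bear on this. The step of a 3.2-fold lower number from compound 1 to compound 3 (0.51 log units; beyond the scatter) and the step of a 7.6-fold lower number from compound 2 to compound 3 (0.88 log units; beyond the scatter) both show that bringing in the 2-hydroxynaphthalen-1-yl group in place of a methoxy-bearing single ring gave a modestly lower number. Compound 4 carries a single ring again, bearing one hydroxy and one methoxy group, so the change runs in the reverse direction to those two steps, and a modest rise in this assay is expected, roughly back toward the value of compound 1. The estimate for compound 4 is 2500 nM, with a range from 900 nM to 7000 nM, corresponding to an expected step of a 2.8-fold higher number from compound 3 to compound 4 (0.45 log units; beyond the scatter).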

Compound 4, half-maximal inhibitory concentration: > 100000 nM
Compound 4 was reported as a limit; the forecaster's own chance of this, stated with the estimate: 5%; at least 40-fold (1.60 log units) between middle value and limit.
By their numbers in this assay, from the lowest: compound 3; then compound 1; then compound 2. At a limit, above all of these: compound 4.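

Compound 4 is reported in this assay only as a limit, not as a number: the limit of > 100000 nM in this assay, at which 1 of the 4 values shown sits.

Replacing the 2-hydroxynaphthalen-1-yl group gives an at least 110-fold higher number from compound 3 to compound 4 (2.05 log units; beyond the scatter) and the comparisons with the two methoxy-bearing single rings give an at least 35-fold higher number from compound 1 to compound 4 (1.54 log units; beyond the scatter) and an at least 14-fold higher number from compound 2 to compound 4 (1.17 log units; beyond the scatter) as well. Having a single ring at this place therefore does not by itself decide the outcome, as compound 1 and compound 2 also carry one, and neither does having a hydroxy group, as compound 3 carries one too.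

From the compounds shown here alone, what remains open is whether the loss depends on the hydroxy and methoxy groups occurring together on one ring. A plain phenyl ring, or a ring with an amine or a carboxylic acid in place of the hydroxy group, could help separate these possibilities.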